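The compounds below may be only part of what the source reports. "The series", "measured", "known", "first", "only" and "open" are said of these compounds alone.

Measured compounds:
Compound 1, `COc1cc(/C=C/c2ccc(NC(=O)/C=C/c3cc(OC)c(O)c(OC)c3)cc2)cc(OC)c1`, with 3080 nM in a functional assay on HT-29 cells (Homo sapiens) for inhibition, read by MTT assay, with a stated time of 48 h; a higher number here means a weaker inhibitor, a lower number a stronger inhibitor.
Compound 2, `COc1cc(/C=C/c2ccc(NC(=O)/C=C/c3ccc([N+](=O)[O-])cc3)cc2)cc(OC)c1`, with 10700 nM in this assay.

Compound 1 holds the lowest number of the two in this assay; its nearest neighbour is compound 2, and the step of a 3.5-fold higher number from compound 1 to compound 2 (0.54 log units; beyond the scatter) lies beyond the scatter. Compound 3, `COc1cc(/C=C/c2ccc(NC(=O)/C=C/c3ccc(Cl)cc3)cc2)cc(OC)c1`, has not yet been measured. It differs from compound 1 as follows: 4-chlorophenyl in place of 4-hydroxy-3,5-dimethoxyphenyl on a double-bonded chain carbon bound to a double-bonded chain carbon. For the measured compounds named here, the only measured step that bears on this change is the one from compound 1 to compound 2, where another group took the same place on the shared core and the number rose by a 3.5-fold higher number from compound 1 to compound 2 (0.54 log units; beyond the scatter). Since compound 3 likewise loses the 4-hydroxy-3,5-dimethoxyphenyl group at that place, a step of similar size and in the same direction, toward a higher number, is expected for a 2.6-fold higher number from compound 1 to compound 3 (0.41 log units; beyond the scatter). On that basis compound 3 is estimated to give 8000 nM in this assay, with a range from 3000 nM to 20000 nM.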

Compound 3, half-maximal inhibitory concentration: 10300 nM
The estimate for compound 3 lay 1.3-fold (0.11 log units) below the measured number, and the stated range covers the measured number.
By their numbers in this assay, from the lowest: compound 1; then compounds 3 and 2 (each within the scatter of the next).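

In this assay, the result shows that the rise seen with 4-nitrophenyl is not confined to that one group: replacing 4-hydroxy-3,5-dimethoxyphenyl with 4-chlorophenyl at the same place on the shared core gives a 3.3-fold higher number from compound 1 to compound 3 (0.52 log units; beyond the scatter) and so a second step beyond the scatter in the same direction. The two replacement groups cannot be told apart here, since chloro in place of nitro on an aromatic carbon gives a 1.0-fold lower number from compound 2 to compound 3 (0.02 log units; within the scatter) in the same assay. Among these three compounds, then, the lowest number belongs to the compound with 4-hydroxy-3,5-dimethoxyphenyl, and neither 4-substituted replacement goes against this.

The compounds shown leave open whether the hydroxy or the methoxy groups of compound 1 account for its lower number, as no compound here carries only one of these on the phenyl ring. Also open, as far as these compounds go, is what an amine or a carboxylic acid would give at that place on the core. Nothing given here accounts for these numbers.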